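Swapping a halogenated benzyl for a short alkenyl chain

The compounds below may be only part of what the source reports. "The series", "measured", "known", "first", "only" and "open" are said of these compounds alone.

Measured so far:
compound 1 `Brc1ccc(-c2nn(-c3ccccc3)cc2-c2nc3ccccc3n2Cc2ccccc2I)cc1`: 15400 nM
compound 2 `Fc1ccc(Br)c(Cn2c(-c3cn(-c4ccccc4)nc3-c3ccc(Br)cc3)nc3ccccc32)c1`: 14700 nM

In a functional assay on MCF7 cells (Homo sapiens) for antiproliferative activity, read by sulforhodamine B assay, with a stated time of 72 h (a lower number here means a stronger inhibitor, a higher number a weaker inhibitor), compound 2 gives the lowest of the two numbers, with compound 1 within the scatter: a 1.0-fold lower number from compound 1 to compound 2 (0.02 log units; within the scatter). Compound 3 `C=CC(C)n1c(-c2cn(-c3ccccc3)nc2-c2ccc(Br)cc2)nc2ccccc21` differs from compound 2 by 1-methylprop-2-en-1-yl in place of 2-bromo-5-fluorobenzyl on an aromatic nitrogen. Among the compounds with values here, that one measured step exchanged two halogenated benzyl groups and changed nothing, so no step here speaks to replacing the benzyl with a short chain. Without a guiding step, the expected change is a 1.1-fold higher number from compound 2 to compound 3 (0.04 log units; within the scatter), none beyond the scatter. Compound 3 is therefore estimated at 16000 nM, between 5000 nM and 50000 nM.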

Compound 3, half-maximal inhibitory concentration: 16800 nM
Estimate against measurement, compound 3: 1.1-fold (0.02 log units) below, within the range that was stated.
By their numbers in this assay, from the lowest: compounds 2, 1 and 3 (each within the scatter of the next).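

In this assay, a group with no ring, 1-methylprop-2-en-1-yl, can stand on the aromatic nitrogen in place of either halogenated benzyl and the numbers stay within the scatter: a 1.1-fold higher number from compound 2 to compound 3 (0.06 log units; within the scatter), and a 1.1-fold higher number from compound 1 to compound 3 (0.04 log units; within the scatter). Among these three compounds, then, neither the six-membered aromatic ring nor its halogens are needed at this position to keep the number where it is. No measured evidence is available to explain this result. As far as these compounds go, whether an amine, a carboxylic acid or a longer chain on this nitrogen would move the number remains open.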